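Changing the Hydroxyl Tail of an Amide Side Chain

A few compounds are considered here, and "the series" means these few. Any claim that something is new, unique, unknown or untested is made for them only; others in the source may bear on it.

Compound 2 `CC(C)Nc1cc(Nc2ccc3ncsc3c2)ncc1C(=O)NCCCO` carries a 3-hydroxypropyl tail on its amide nitrogen, and in an ADME assay on microsomes from liver (Homo sapiens) for metabolic stability (a lower number here means that less of the compound is left, a higher number that more of the compound is left), compound 2 gives 84%. For the measured compounds named here, only one other compound has a number here: compound 3 `CCNC(=O)c1cnc(Nc2ccc3ncsc3c2)cc1NC(C)C`, whose tail lacks the hydroxymethyl, gives 74%. The step of a number 10 percentage points lower from compound 2 to compound 3 (within the scatter) stays inside the usual scatter, so the two numbers cannot be put in order. Compound 1 `CC(C)Nc1cc(Nc2ccc3ncsc3c2)ncc1C(=O)NC[C@@H](C)C(C)(C)O` has no result in this assay: for compound 1 the entry reads "not determined" (no result reported).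

Compound 4 `CC(C)Nc1cc(Nc2ccc3ncsc3c2)ncc1C(=O)NCCC(C)(C)O` keeps the tail but alters its end: 1-hydroxy-1-methylethyl in place of hydroxymethyl on a saturated chain carbon, two bonds along the chain from an amide-type nitrogen. Going by the values given here, no measured step matches this change exactly; the nearest, from compound 2 to compound 3, shows that taking the hydroxymethyl away moves the number no further than the scatter. Putting 1-hydroxy-1-methylethyl in its place is expected to do no more. Compound 4 is therefore estimated at 80%, between 65% and 92%. The expected step of a number 4 percentage points lower from compound 2 to compound 4 (within the scatter) is estimated to remain within the scatter.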

Compound 4, percent of the compound remaining: 79%
Estimate against measurement, compound 4: 1 percentage points above, and the stated range covers the measured number.
By their numbers in this assay, from the lowest: compounds 3, 4 and 2 (each within the scatter of the next).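

In this assay the hydroxyl tail can now be varied at its end as well as removed: 1-hydroxy-1-methylethyl in place of hydroxymethyl gives a number 5 percentage points lower from compound 2 to compound 4 (within the scatter), even though the entering group has 4 heavy atoms and the leaving group has 2. Set against hydrogen at the same place on the saturated chain carbon, 1-hydroxy-1-methylethyl gives a number 5 percentage points higher from compound 3 to compound 4 (within the scatter), so hydrogen, hydroxymethyl and 1-hydroxy-1-methylethyl cannot be put in order here. Nothing in the available data speaks to what lies behind these close numbers.

Still open, on these data alone, is whether a different kind of group at this place, such as an amine, a carboxylic acid or a longer chain, would move the number beyond the scatter. Also open, as far as these compounds go, is what a methyl group further along the chain would do on its own.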